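The source may report more compounds than this note shows. Statements on the series, on what has been measured and on what is new or still open speak of the compounds shown alone.

Measured compounds:
compound 1, `COc1ccc(C2CC(c3cc4ccc(O)cc4oc3=O)=NN2c2ccc(F)cc2)cc1`: 7100 nM
compound 2, `COc1ccc(C2CC(c3cc4ccc(O)cc4oc3=O)=NN2c2ccc(Br)cc2)cc1`: 6500 nM

Both were tested in a functional assay on A549 cells (Homo sapiens) for inhibition, read by sulforhodamine B assay, with a stated time of 48 h; on this read-out higher numbers stand for weaker inhibition and lower numbers for stronger inhibition. Compound 1 gives the larger of the two numbers, but the step to compound 2 lies within the scatter: a 1.1-fold lower number from compound 1 to compound 2 (0.04 log units; within the scatter). That exchange of one halogen for another on an aromatic carbon left the read-out essentially unchanged.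

Compound 3, `COc1ccc(C2CC(c3cc4ccc(O)cc4oc3=O)=NN2c2ccccc2)cc1`, has not been measured. It differs from compound 1 by hydrogen in place of fluoro on an aromatic carbon, so the 4-fluorophenyl of compound 1 becomes a plain phenyl. Going by the values given here, the one measured step on this aromatic carbon, bromo in place of fluoro, stayed within the scatter, and no measured pair shows what removing the halogen altogether does. Nothing in the measured data therefore points in either direction. Compound 3 is expected to show no step beyond the scatter in this assay, and the estimated step is a 1.0-fold lower number from compound 1 to compound 3 (0.01 log units; within the scatter). Compound 3 is accordingly estimated at 7000 nM, with a range from 3500 nM to 14000 nM.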

Compound 3, half-maximal inhibitory concentration: 6300 nM
Estimate against measurement, compound 3: 1.1-fold (0.05 log units) above, and the stated range covers the measured number.
By their numbers in this assay, from the lowest: compounds 3, 2 and 1 (each within the scatter of the next).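

In this assay hydrogen in place of fluoro gives a 1.1-fold lower number from compound 1 to compound 3 (0.05 log units; within the scatter) and hydrogen in place of bromo gives a 1.0-fold lower number from compound 2 to compound 3 (0.01 log units; within the scatter) so taking the halogen away altogether moves the read-out no more than swapping one halogen for another did. The earlier pair compared only two halogens and could not show whether having a halogen at this place matters; now the 4-fluorophenyl to phenyl change shows that, among these three compounds, a halogen on this aromatic carbon, para to a large group, is not needed to keep the number where it stands. No supporting information is available to explain why this position responds so little to these changes.

Fluoro, bromo and hydrogen are only three closely related choices, so this flat result says little about how a very different group at the same place, such as an amine, a carboxylic acid or a longer chain, would behave. The compounds shown also leave open whether changes elsewhere on the shared core would move the number any further than these did.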